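From compound 1 to compound 3: the sulfonyl sulfur group

The compounds below may be only part of what the source reports. "The series", "measured", "known", "first", "only" and "open" are said of these compounds alone.

In an ADME assay on the whole organism (Rattus norvegicus, strain Sprague-Dawley), read by LC-MS, with a stated time of 30 min, at a dose of 1 mg/kg by the intravenous route (a lower number here means that the compound disappears faster, a higher number that the compound lasts longer), compound 1 `N#Cc1ccc(O[C@H]2CN(S(=O)(=O)c3ccc(C(F)(F)F)cc3)C[C@@]2(O)CO)cc1F` gives 2 h and compound 2 `N#Cc1ccc(O[C@H]2CN(S(=O)(=O)c3ccc(Cl)cc3Cl)C[C@@]2(O)CN)cc1F` gives 3.2 h. These two numbers lie within the usual scatter of each other, so the data set neither compound apart from the other. Among the compounds with values here, the two compounds are not related by a change in one place, and the series therefore holds no measured step to use as a guide.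

The next compound is compound 3 `N#Cc1ccc(O[C@H]2CN(S(=O)(=O)c3ccccc3C#N)C[C@@]2(O)CO)cc1F`, which keeps the rest of compound 1 and carries 2-cyanophenyl in place of 4-(trifluoromethyl)phenyl on a sulfonyl sulfur. Within the data shown here, with no measured step for this kind of change, no direction can be argued with confidence in this assay. The expectation rests on compound 1 at 2 h, and no shift beyond the scatter is expected. The expected change is a 1.1-fold lower number from compound 1 to compound 3 (0.05 log units; within the scatter), which stays within the scatter. The estimate for compound 3 is 1.8 h, with an expected range of 0.9 h to 3.6 h.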

Compound 3, mean residence time: 0.4 h
Compound 3: the middle estimate sits 4.5-fold (0.65 log units) above what was measured, and the stated range ends above it.
By their numbers in this assay, from the lowest: compound 3; then compounds 1 and 2 (each within the scatter of the next).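

In this assay, the aryl group on a sulfonyl sulfur whose other neighbours are sulfonamide nitrogen in a ring proves to be a place where the read-out can move: with the rest of compound 1 kept, 2-cyanophenyl in place of 4-(trifluoromethyl)phenyl gives a 5.0-fold lower number from compound 1 to compound 3 (0.70 log units; beyond the scatter). Within the data shown here, compound 1 and compound 2 could not show this, as they are not related by a change in one place, so this is the first measured step and it points towards a compound that disappears faster. Nothing at hand accounts for this drop.

This single step does not separate the loss of the trifluoromethyl group from the arrival of the nitrile, nor does it show whether the change would have the same size on another compound of the series. It also leaves open how the number would respond to a plain phenyl group, or to a phenyl ring carrying a methoxy group or an amine, on the same sulfonyl sulfur.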